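Removing one methoxy group from a trimethoxyphenyl chalcone

The source may report more compounds than this note shows. Statements on the series, on what has been measured and on what is new or still open speak of the compounds shown alone.

Compound 1 `COc1ccc(-c2cc(/C=C/C(=O)c3ccc(N)cc3)[nH]n2)cc1`: 29400 nM
Compound 2 `COc1cc(-c2cc(/C=C/C(=O)c3ccc(N)cc3)[nH]n2)cc(OC)c1OC`, a limit: > 100000 nM
Compound 3 `COc1ccc(C(=O)/C=C/c2cc(-c3cc(OC)c(OC)c(OC)c3)n[nH]2)cc1OC`, a limit: > 100000 nM

In a functional assay on RPMI-8226 cells (Homo sapiens) for inhibition, read by sulforhodamine B assay, with a stated time of 48 h (on this read-out lower numbers stand for higher toxicity in this test and higher numbers for lower toxicity in this test), compound 1 gives 29400 nM. For compound 2 this assay reports only a limit, > 100000 nM, so it stands at the upper edge of the numbers shown and no value of its own is known. Compound 3 likewise sits at a limit, > 100000 nM. Going by the values given here, the only measured step between two compounds that differ in one place, a step that the two limits leave unreadable from compound 2 to compound 3, changes the group on the carbonyl carbon and does not touch the trimethoxyphenyl ring.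

Compound 4 `COc1ccc(-c2cc(/C=C/C(=O)c3ccc(N)cc3)[nH]n2)cc1OC` differs from compound 2 by hydrogen in place of methoxy on an aromatic carbon. Among the compounds with values here, no measured step follows this change; the values of compound 1 and compound 2 only show that the ring with a single methoxy group gave a number while the ring with three gave none. A move towards the value of compound 1 is expected, but of unknown size, and the chance that this assay again reports only a limit remains real. Compound 4 is therefore estimated at 60000 nM, within 20000 nM to 150000 nM. The step expected here is an at least 1.6-fold lower number from compound 2 to compound 4 (0.22 log units; that floor lies within the scatter).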

Compound 4, concentration lethal to 50% of the cells: > 100000 nM
Compound 4 gave a limit, no number; the forecaster's own chance of this, stated with the estimate: 40%; at least 1.6-fold (0.22 log units) between middle value and limit.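

Compound 4 carries a methoxy group on an aromatic carbon where compound 1 has hydrogen, and in this assay this single change gives an at least 3.4-fold higher number from compound 1 to compound 4 (0.53 log units; beyond the scatter). The earlier compounds could only set a ring with one methoxy group against a ring with three, whereas this pair shows that one added methoxy group is enough to move the read-out from a number to a limit, leaving compound 1 as the only compound shown with a value of its own. Removing a methoxy group from compound 2 does not bring back a number, and the step between these two compounds cannot be read, because both ends are limits: the limit of > 100000 nM in this assay, at which 3 of the 4 values shown sit.

How far compound 2 and compound 4 really lie beyond that limit stays unknown, so the compounds shown cannot tell whether the third methoxy group changes anything further. On these data alone, it also stays open whether this effect belongs to methoxy itself or would follow any group on that aromatic carbon, which a hydroxyl group, a fluorine atom or a longer ethoxy chain there could help to separate.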